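Prostacyclin synthase inhibition: aryloxy variation on the shared core

The source may report more compounds than this note shows. Statements on the series, on what has been measured and on what is new or still open speak of the compounds shown alone.

Measured so far:
compound 1 `Cc1ccc(OC(C)(C)C2OCC(C/C=C\CCC(=O)O)C(c3cccnc3)O2)cc1` — 25000 nM
compound 2 `COc1ccccc1OC(C)(C)C1OCC(C/C=C\CCC(=O)O)C(c2cccnc2)O1` — 51000 nM

In an assay for inhibition of prostacyclin synthase (Homo sapiens), using microsomes (on this read-out lower numbers stand for stronger inhibition and higher numbers for weaker inhibition), compound 2 gives the highest of the two numbers recorded; its nearest neighbour is compound 1, and the step of a 2.0-fold higher number from compound 1 to compound 2 (0.31 log units; beyond the scatter) is the only one measured so far. Compound 3 `CC(C)(Oc1ccccc1[N+](=O)[O-])C1OCC(C/C=C\CCC(=O)O)C(c2cccnc2)O1` is not yet measured. It differs from compound 2 by nitro in place of methoxy on an aromatic carbon, ortho to a large group. Going by the values given here, no measured step exchanges one small substituent for another on the same aryl ring; the single step in hand swaps the whole aryl group and stays modest. With nothing to argue for a large move in either direction, compound 3 is expected to remain near compound 2, with a 1.3-fold lower number from compound 2 to compound 3 (0.11 log units; within the scatter) an estimated step that need not exceed the scatter. The estimate for compound 3 in this assay is 40000 nM, expected within 15000 nM to 120000 nM.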

Compound 3, half-maximal inhibitory concentration: < 1000 nM
Compound 3: a limit, no number; the forecaster's own chance of this, stated with the estimate: 15%; at least 40-fold (1.60 log units) between middle value and limit.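

Going by these compounds alone, on the aryl ring, the group on the aromatic carbon ortho to a large group carries far more weight than the only earlier step suggested: nitro in place of methoxy gives an at least 51-fold lower number from compound 2 to compound 3 (1.70 log units; beyond the scatter). The 2-nitrophenyl group also separates clearly from the 4-methylphenyl group, with an at least 25-fold lower number from compound 1 to compound 3 (1.39 log units; beyond the scatter), whereas the earlier exchange of whole aryl groups stayed modest. The reading for compound 3 in this assay is a limit and not a number: the limit of < 1000 nM in this assay, at which 1 of the 3 values shown sits.

From the compounds shown here alone, the true size of both new steps therefore stays open. The compounds shown also do not tell whether a nitrile or an amine on the same aromatic carbon would behave like nitro, or whether nitro elsewhere on the ring would give a similar step.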